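The source may hold more compounds than are shown below. What is called first, only, known or untested is meant among the compounds shown, and "the series" means these compounds.

Compound 1, with the structure `CNCC(=O)Nc1cc(OC)ccc1C(=O)c1ccc(OC)c2c1OC(C)(C)C=C2`, is the starting point of this small series. In a functional assay on MCF7 cells (Homo sapiens) for antiproliferative activity, read by MTT assay, with a stated time of 48 h (on this read-out higher numbers stand for weaker inhibition and lower numbers for stronger inhibition), compound 1 gives 820 nM. Compound 2, with the structure `CCNCC(=O)Nc1cc(OC)ccc1C(=O)c1ccc(OC)c2c1OC(C)(C)C=C2`, differs from compound 1 in one spot only, namely (methyl in place of hydrogen on a saturated chain carbon bound to an amine nitrogen). This change weakens the compound: the measured step is a 6.3-fold higher number from compound 1 to compound 2 (0.80 log units; beyond the scatter), and in this assay compound 2 gives 5200 nM.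

Compound 3, with the structure `C=C(c1ccc(OC)cc1NC(=O)CNC)c1ccc(OC)c2c1OC(C)(C)C=C2`, carries a different core; the difference between its core and that of compound 1 is not broken down here. In this assay compound 3 gives 400 nM, the lowest number of the three measured compounds and therefore the strongest inhibitor among them, with both the step to compound 1 and the step to compound 2 lying beyond the usual scatter.

Compound 4, with the structure `C=C(c1ccc(OC)cc1NC(=O)CNCC)c1ccc(OC)c2c1OC(C)(C)C=C2`, is not yet measured. It relates to compound 3 exactly as compound 2 relates to compound 1: the difference is methyl in place of hydrogen on a saturated chain carbon bound to an amine nitrogen, the same change at the same kind of place. Since this change was seen once, and on that occasion produced the step from compound 1 to compound 2 of a 6.3-fold higher number from compound 1 to compound 2 (0.80 log units; beyond the scatter), the expectation is that compound 4 will show a step of similar size, estimated as a 5.8-fold higher number from compound 3 to compound 4 (0.76 log units; beyond the scatter). The core is different, so the size may not carry over exactly, and the expected range is wide. For compound 4 the estimated value in this assay is 2300 nM, expected to lie between 900 nM and 6000 nM.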

Compound 4, half-maximal inhibitory concentration: 2100 nM
Beside the measured number, compound 4's estimate is 1.1-fold (0.04 log units) above it; the range from low to high includes it.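

In this assay, going from methylamino to ethylamino on the second core gives a 5.3-fold higher number from compound 3 to compound 4 (0.72 log units; beyond the scatter), so the change weakens inhibition here as it did on the first core. Set side by side, the two steps agree: the same change on two cores in this assay, a 6.3-fold higher number (0.80 log units; beyond the scatter) from compound 1 to compound 2 and a 5.3-fold higher number (0.72 log units; beyond the scatter) from compound 3 to compound 4, 1.2-fold (0.08 log units) apart, within the scatter of two such steps. Within these two pairs, then, the loss of activity carried over from one core to the other in both direction and size, but two pairs do not make a general rule, and these numbers do not explain why the added methyl weakens inhibition or show that the same step would appear on a further core.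

The compounds shown leave open how the trend continues along the amine, for instance whether a longer chain such as propyl would weaken inhibition further, or whether a primary amine, with hydrogen in place of the methyl of methylamino, would strengthen or weaken it on either core. They also leave open whether the two cores would keep the same close agreement with a larger or branched group such as isopropyl, or in cell lines other than the one tested here.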